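The Same Ring Swap Tested on Two Cores

The source may report more compounds than this note shows. Statements on the series, on what has been measured and on what is new or still open speak of the compounds shown alone.

Measured so far:
compound 1 `CNC(=O)c1cc(Oc2ccc(NC(=O)c3nn(-c4ccc(Br)cc4F)c(=O)cc3C)cc2F)ccn1`: 9360 nM
compound 2 `CNC(=O)c1cc(Oc2ccc(NC(=O)c3nn(-c4ccccc4OC(F)(F)F)c(=O)cc3C)cc2F)ccn1`: > 40000 nM, a limit of the assay
compound 3 `Cc1cc(=O)n(-c2ccc(Br)cc2F)nc1C(=O)Nc1ccc(Oc2ncnc3ccsc23)cc1`: 9360 nM

In a functional assay on MCF7 cells (Homo sapiens) for cytotoxicity, read by MTT assay, with a stated time of 72 h (a lower number here means a stronger inhibitor, a higher number a weaker inhibitor), compound 1 gives 9360 nM. Compound 2 reaches only a limit of the assay in this assay, > 40000 nM. The change 2-(trifluoromethoxy)phenyl in place of 4-bromo-2-fluorophenyl on an aromatic nitrogen therefore produced an at least 4.2-fold higher number from compound 1 to compound 2 (0.63 log units; beyond the scatter), a step that ends at the limit of > 40000 nM in this assay, at which 1 of the 3 values shown sits.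

Compound 3 gives 9360 nM in this assay, level with compound 1 at the digits shown. How the core of compound 3 differs from the core of compound 1 is not broken down here.

Compound 4 `Cc1cc(=O)n(-c2ccccc2OC(F)(F)F)nc1C(=O)Nc1ccc(Oc2ncnc3ccsc23)cc1` is not yet measured. It differs from compound 3 by 2-(trifluoromethoxy)phenyl in place of 4-bromo-2-fluorophenyl on an aromatic nitrogen, the same change at the same place as from compound 1 to compound 2.

The step from compound 3 to compound 4 is expected to be a 4.8-fold higher number from compound 3 to compound 4 (0.68 log units; beyond the scatter), because the matching step gave an at least 4.2-fold higher number from compound 1 to compound 2 (0.63 log units; beyond the scatter). Compound 4 is therefore estimated at 45000 nM, most likely reported as a limit, between 20000 nM and 150000 nM.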

Compound 4, half-maximal inhibitory concentration: 23800 nM
Beside the measured number, compound 4's estimate is 1.9-fold (0.28 log units) above it; the range from low to high includes it.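

On the core of compound 3, placing 2-(trifluoromethoxy)phenyl where 4-bromo-2-fluorophenyl stood gave a 2.5-fold higher number from compound 3 to compound 4 (0.41 log units; beyond the scatter) in this assay, which is the same direction as on the core of compound 1. Compound 2 stands at > 40000 nM, which is a limit of the assay and not a number. The two cores therefore show that the direction carried over, but not that the size of the step did: the same change on two cores in this assay, an at least 4.2-fold higher number (0.63 log units; beyond the scatter) from compound 1 to compound 2 and a 2.5-fold higher number (0.41 log units; beyond the scatter) from compound 3 to compound 4; the limit leaves it open whether they differ.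

The compounds shown leave open whether the step would hold on a third core. They also leave open how a phenyl ring bearing an amine or a carboxylic acid would behave at the same aromatic nitrogen.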